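Removing one ring chloro from a weakly active benzyl purine

This account rests on a few compounds, and the source may have more. Where it says the series, first, only, none or still open, it means among the compounds named here.

Compound 1 `ClCc1ccc(Cn2cnc3nc(Cl)nc(Cl)c32)cc1`: 10200 nM
Compound 2 `ClCc1cccc(Cn2cnc3nc(Cl)nc(Cl)c32)c1`: 220 nM

In a functional assay on T47D cells (Homo sapiens) for cytotoxicity, read by sulforhodamine B assay, with a stated time of 48 h (on this read-out lower numbers stand for stronger inhibition of growth and higher numbers for weaker inhibition of growth), compound 1 gives 10200 nM, the highest of the two numbers; compound 2 gives 220 nM, a lower number beyond the scatter. Compound 3 `ClCc1ccc(Cn2cnc3ncnc(Cl)c32)cc1` differs from compound 1 in one place: hydrogen in place of chloro on an aromatic carbon. Going by the values given here, no measured pair shows what this change does in this assay. A modest step towards weaker inhibition of growth, or none beyond the scatter, is expected, as a 2.0-fold higher number from compound 1 to compound 3 (0.29 log units; within the scatter). Compound 3 is therefore estimated at 20000 nM, most likely within 6000 nM to 70000 nM.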

Compound 3, concentration for 50% growth inhibition: 1280 nM
The estimate for compound 3 lay 16-fold (1.19 log units) above the measured number; the measured number lies below the stated range.
By their numbers in this assay, from the lowest: compound 2; then compound 3; then compound 1.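

In this assay hydrogen in place of chloro on an aromatic carbon between two ring nitrogen atoms gives an 8.0-fold lower number from compound 1 to compound 3 (0.90 log units; beyond the scatter) and this step is beyond the scatter. For this pair, the chloro at this position is therefore not needed for inhibition of growth, and its loss strengthens it. Nothing shown gives a reason for this step. Going by these compounds, it remains open whether an amine or a methoxy group at this position would improve on hydrogen. On these data alone, it also remains open whether the same change would have a similar effect on compound 2.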